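The compounds below may be only part of what the source reports. "The series", "measured", "known", "first", "only" and "open" are said of these compounds alone.

Compound 1 `CC(=O)Oc1ccccc1C(=O)OCC[Se]C#N` and compound 2 `CC(=O)Oc1ccccc1C(=O)[Se]CC[Se]C#N` share the same core and were both tested in a functional assay on UACC-903 cells (Homo sapiens) for antiproliferative activity, read by MTT assay, with a stated time of 48 h; a lower number here means a stronger inhibitor, a higher number a weaker inhibitor. In this assay compound 1 gives 14500 nM, while compound 2 gives 15800 nM. Going by the values given here, the one measured step, a 1.1-fold higher number from compound 1 to compound 2 (0.04 log units; within the scatter), changes only the group on the carbonyl carbon. Compound 2 therefore has the highest number of the two, but its nearest neighbour, compound 1, sits within the scatter, so the two cannot be ordered.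

Compound 3 `CC(=O)Oc1ccccc1C(=O)NCCSC#N` is not yet measured. Its change from compound 2 is a group of 6 heavy atoms (3 carbon, 2 nitrogen, 1 sulfur; no ring) in place of a group of 6 heavy atoms (3 carbon, 1 nitrogen, 2 selenium; no ring), on a carbonyl carbon. Among the compounds with values here, the only step on record, from compound 1 to compound 2, also sits on this carbonyl carbon and stayed within the scatter, but it kept a selenium-containing group, whereas this change removes selenium entirely and brings in a hydrogen-bond donor. Because the measured step of a 1.1-fold higher number from compound 1 to compound 2 (0.04 log units; within the scatter) was so small, the expected step of a 1.6-fold higher number from compound 2 to compound 3 (0.20 log units; within the scatter) is a modest rise toward a weaker inhibitor. Compound 3 is estimated at 25000 nM, with a range from 8000 nM to 80000 nM.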

Compound 3, half-maximal inhibitory concentration: > 50000 nM
Compound 3 gave a limit, no number; the forecaster's own chance of this, stated with the estimate: 15%; middle value at least 2.0-fold (0.30 log units) from the limit.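

The group on the carbonyl carbon does matter in this assay: compound 1 and compound 2 could not be told apart, yet the (2-(cyanosulfanyl)ethyl)amino group gives an at least 3.1-fold higher number from compound 2 to compound 3 (0.50 log units; beyond the scatter) and an at least 3.4-fold higher number from compound 1 to compound 3 (0.53 log units; beyond the scatter). Both steps lie beyond the scatter, so this position tolerates the two selenium-containing groups shown but not this sulfur-containing, nitrogen-linked group. Compound 3 gives a limit and not a number, so the full size of both steps stays unknown: the limit of > 50000 nM in this assay, at which 1 of the 3 values shown sits.

This single change replaces selenium with sulfur and also puts a nitrogen on the carbonyl carbon, so the compounds shown cannot say which of the two accounts for the weaker result. A (2-(cyanoselanyl)ethyl)amino group or a 2-(cyanosulfanyl)ethoxy group on the same carbonyl carbon would separate these two parts of the change.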